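Benzyl in Place of Dimethoxyphenyl on the Amine Nitrogen

This account rests on a few compounds, and the source may have more. Where it says the series, first, only, none or still open, it means among the compounds named here.

For the measured compounds named here, compound 2 `COc1ccc(N/C(CCNC2=CC(=O)c3ccccc3C2=O)=N\S(=O)(=O)c2ccc(C)cc2)c(OC)c1` holds the highest of the two numbers so far, though its nearest neighbour lies within the scatter: in a functional assay on MCF7 cells (Homo sapiens) for cytotoxicity, read by MTT assay, with a stated time of 48 h (a lower number here means a stronger inhibitor, a higher number a weaker inhibitor), compound 2 gives 30200 nM, while compound 1 `Cc1ccc(S(=O)(=O)/N=C(/CCNC2=CC(=O)c3ccccc3C2=O)Nc2ccccc2I)cc1` gives 15500 nM, a gap that is a 1.9-fold higher number from compound 1 to compound 2 (0.29 log units; within the scatter). Compound 3 `Cc1ccc(S(=O)(=O)/N=C(/CCNC2=CC(=O)c3ccccc3C2=O)NCc2ccccc2)cc1` has not yet been measured. It differs from compound 2 by benzyl in place of 2,4-dimethoxyphenyl on an amine nitrogen. Going by the values given here, the only measured step touching this position is a 1.9-fold higher number from compound 1 to compound 2 (0.29 log units; within the scatter), which exchanged one aryl group for another on the amine nitrogen and stayed within the scatter; no measured step replaces an aryl group with a benzyl group, so that particular change has no number behind it. The account therefore expects compound 3 to land near compound 2, a step of a 1.2-fold lower number from compound 2 to compound 3 (0.08 log units; within the scatter) with no direction beyond the scatter. Compound 3 is estimated at 25000 nM, with a range from 8000 nM to 75000 nM.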

Compound 3, half-maximal inhibitory concentration: 3630 nM
Beside the measured number, compound 3's estimate is 6.9-fold (0.84 log units) above it, outside the stated range (below it).
By their numbers in this assay, from the lowest: compound 3; then compounds 1 and 2 (each within the scatter of the next).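

The amine nitrogen turns out to be a position where the choice of group matters in this assay: the exchange of one aryl group for another had stayed within the scatter, whereas benzyl gives an 8.3-fold lower number from compound 2 to compound 3 (0.92 log units; beyond the scatter) and, against 2-iodophenyl, a 4.3-fold lower number from compound 1 to compound 3 (0.63 log units; beyond the scatter). Both steps lie beyond the scatter and run the same way, so compound 3 has the lowest number of the three. No measurement shown here accounts for this difference.

The compounds shown leave open whether the lower number goes with the benzyl group as such or with its ring carrying no substituent, a question that plain phenyl or 2-iodobenzyl on this nitrogen would address. Going by these compounds, it also remains open how a longer chain, such as 2-phenylethyl, would read in this assay.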